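A few compounds are considered here, and "the series" means these few. Any claim that something is new, unique, unknown or untested is made for them only; others in the source may bear on it.

In an ADME assay on MT4 cells (Homo sapiens) for cytotoxicity, read by MTT assay, with a stated time of 4 days (a lower number here means that less compound is tolerated, a higher number that more compound is tolerated), compound 1 `C/C(=N\NC(=O)COc1cccc2ccccc12)c1ccc([N+](=O)[O-])cc1` gives 89.3 ug/mL and compound 2 `O=C(COc1cccc2ccccc12)N/N=C/c1ccccc1Cl` gives 56.2 ug/mL as its reading. These two numbers lie within the usual scatter of repeated measurements, so compound 1 cannot be told apart from compound 2 on this evidence. Going by the values given here, no two measured compounds differ in one place only, which means that no measured step is available as a guide.

The next compound, compound 3 `C/C(=N\NC(=O)COc1cccc2ccccc12)c1ccc(O)cc1`, keeps the core of compound 1 and exchanges one group, with hydroxy in place of nitro on an aromatic carbon, para to a large group (hydroxy in place of nitro on an aromatic carbon). The data do not show what this exchange does in this assay. Among the compounds with values here, the only anchors are compound 1 at 89.3 ug/mL and compound 2 at 56.2 ug/mL, so no change beyond the scatter is expected. The estimated step of a 1.4-fold lower number from compound 1 to compound 3 (0.14 log units; within the scatter) is therefore small, and any drift is expected to be slight. For compound 3 the expected value is 65 ug/mL with an estimated range from 28 ug/mL to 130 ug/mL around it.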

Compound 3, half-maximal cytotoxic concentration: 68.8 ug/mL
Estimate against measurement, compound 3: 1.1-fold (0.02 log units) below; measured number inside the range.
By their numbers in this assay, from the lowest: compounds 2, 3 and 1 (each within the scatter of the next).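

In this assay, putting hydroxy in place of nitro on an aromatic carbon, para to a large group, gives a 1.3-fold lower number from compound 1 to compound 3 (0.11 log units; within the scatter). Going by these compounds alone, this is the first measured change in a single place, and it shows that 4-nitrophenyl and 4-hydroxyphenyl cannot be told apart in this assay, even though the two groups differ in their heavy atoms and in whether they carry a hydrogen-bond donor. For this one pair, then, those differences at this position come with no readable difference in how much compound the cells tolerate, and nothing measured here gives a reason for that result.

A single pair of groups cannot show whether this position tolerates every exchange, so an amine, a carboxylic acid or a longer chain such as butoxy in the same place could still move the number beyond the scatter. As far as these compounds go, it also remains open whether hydroxy in place of nitro would behave the same way on a different aromatic carbon or on a core other than that of compound 1.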